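Compound 1 to compound 4: ester chain out, oxazole in

This account rests on a few compounds, and the source may have more. Where it says the series, first, only, none or still open, it means among the compounds named here.

- compound 1 `CCOC(=O)CCCN(c1ccccc1)[C@H]1c2cc(C#N)ccc2OC(C)(C)[C@@H]1O`: > 30000 nM (a limit)
- compound 2 `CCOC(=O)CN(c1nc(C)cs1)[C@H]1c2cc(C#N)ccc2OC(C)(C)[C@@H]1O`: 84000 nM
- compound 3 `CCOC(=O)CN(c1nc2ccccc2o1)[C@H]1c2cc(C#N)ccc2OC(C)(C)[C@@H]1O`: > 30000 nM (a limit)

All three values come from a functional assay (aorta) with Rattus norvegicus as the target; on this read-out lower numbers stand for stronger inhibition and higher numbers for weaker inhibition. In this assay compound 1 gives > 30000 nM, which is a limit and not a number. The same holds for one other compound: the limit of > 30000 nM in this assay, at which 2 of the 3 values shown sit.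

Compound 4 `CC1(C)Oc2ccc(C#N)cc2[C@H](N(Cc2ncco2)c2ccccc2)[C@H]1O` differs from compound 1 by one change: 1,3-oxazol-2-yl in place of 2-(ethoxycarbonyl)ethyl on a saturated chain carbon bound to a nitrogen on an aromatic ring. In short, 1,3-oxazol-2-yl takes the place of 2-(ethoxycarbonyl)ethyl.

For the measured compounds named here, the only measured step is a step that the limit leaves unreadable from compound 2 to compound 3. Going by the values given here, it concerns a different group and has no readable size, so no measured step speaks directly to this change. Among the compounds with values here, the one real number is from compound 2, at 84000 nM, and it suggests that compound 4 will stay in the same weak region, with no clear direction of change. The step expected in this assay is a step that the limit leaves unreadable from compound 1 to compound 4, and it may well remain unreadable. For compound 4 the estimated value is 40000 nM, with an expected range from 12000 nM to 100000 nM.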

Compound 4, half-maximal inhibitory concentration: > 30000 nM
Compound 4 gave a limit, no number; the forecaster's own chance of this, stated with the estimate: 65%; the middle value lies beyond the limit too.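

In this assay, for the compounds shown here, compound 1 and compound 4 both end at a limit rather than a number, and no step between them can be read. The compounds shown leave open whether 1,3-oxazol-2-yl or 2-(ethoxycarbonyl)ethyl gives stronger inhibition, and how strong either compound really is.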